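Chain extension on the sulfur-bound carbon of the shared core

A few compounds are considered here, and "the series" means these few. Any claim that something is new, unique, unknown or untested is made for them only; others in the source may bear on it.

Compound 3 `CSc1nc(NCc2ccc(-c3ccccn3)cc2)c2[nH]nc(C(C)C)c2n1` stands highest of the three measured numbers in a functional assay on HT cells (Homo sapiens) for antiproliferative activity, read by fluorescence, with a stated time of 72 h (on this read-out higher numbers stand for weaker inhibition of growth and lower numbers for stronger inhibition of growth), where compound 3 gives 783 nM. Compound 1 `CC(C)c1n[nH]c2c(NCc3ccc(-c4ccccn4)cc3)nc(SCCO)nc12` gives 48 nM and compound 2 `CC(C)c1n[nH]c2c(NCc3ccc(-c4ccccn4)cc3)nc(SCC(O)CN3CCNCC3)nc12` gives 332 nM. The steps into compound 3 run a 16-fold higher number from compound 1 to compound 3 (1.21 log units; beyond the scatter) and a 2.4-fold higher number from compound 2 to compound 3 (0.37 log units; beyond the scatter), the first large and the second modest, so any group placed on the saturated chain carbon bound to the sulfur has so far gone with a lower number than bare hydrogen; the size depends on the group, since a 6.9-fold higher number from compound 1 to compound 2 (0.84 log units; beyond the scatter) shows the larger group of compound 2 above compound 1. Compound 4 `CC(C)c1n[nH]c2c(NCc3ccc(-c4ccccn4)cc3)nc(SCCNC(N)=O)nc12` carries ureidomethyl in place of hydrogen on a saturated chain carbon bound to a sulfur, that is methylsulfanyl to (2-ureidoethyl)sulfanyl. Both steps into compound 3 bear on this change, as each also places a chain with hydrogen-bond donors on this carbon, and both point the same way. A lower number than compound 3 is therefore expected for compound 4, with a step of a 5.2-fold lower number from compound 3 to compound 4 (0.72 log units; beyond the scatter). Compound 4 is estimated at 150 nM, within a range from 50 nM to 450 nM.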

Compound 4, concentration for 50% growth inhibition: 240 nM
Estimate against measurement, compound 4: 1.6-fold (0.20 log units) below, within the range that was stated.
By their numbers in this assay, from the lowest: compound 1; then compounds 4 and 2 (each within the scatter of the next); then compound 3.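

In this assay ureidomethyl on the saturated chain carbon bound to a sulfur also goes with a lower number than hydrogen, with a 3.3-fold lower number from compound 3 to compound 4 (0.51 log units; beyond the scatter) as the step, so all three groups shown at this carbon now lie on the same side of compound 3 and none of the compounds shown goes against this. The direction does not fix the size: ureido in place of hydroxy, two bonds along the chain from a sulfur, gives a 5.0-fold higher number from compound 1 to compound 4 (0.70 log units; beyond the scatter) as its step, and compound 1 remains the lowest of the series. Ureidomethyl and the much larger 1-hydroxy-2-(piperazin-1-yl)ethyl are not separated, since a 1.4-fold lower number from compound 2 to compound 4 (0.14 log units; within the scatter) is the step between them.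

Going by these compounds, whether a carboxylic acid or a primary amine at the chain end, or a longer chain ending in hydroxy, would stand nearer compound 1 or compound 3 remains open. Nothing shown gives a reason for these differences.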